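A few compounds are considered here, and "the series" means these few. Any claim that something is new, unique, unknown or untested is made for them only; others in the source may bear on it.

Three esters sharing one core have been tested in a functional assay on PC-3 cells (Homo sapiens) for cytotoxicity, read by MTT assay, with a stated time of 72 h; on this read-out lower numbers stand for stronger inhibition and higher numbers for weaker inhibition. Compound 1 `COC(=O)c1ccc(/C=C/C(=O)c2cc(OC)ccc2OC)cc1` gives 4850 nM. Compound 2 `CCOC(=O)c1ccc(/C=C/C(=O)c2cc(OC)ccc2OC)cc1` gives 5700 nM, and compound 3 `COc1ccc(OC)c(C(=O)/C=C/c2ccc(C(=O)OC(C)C)cc2)c1` gives 6740 nM. Compound 1 carries the lowest of the three numbers, but the differences are small: a 1.2-fold higher number from compound 1 to compound 2 (0.07 log units; within the scatter), a 1.4-fold higher number from compound 1 to compound 3 (0.14 log units; within the scatter) and a 1.2-fold higher number from compound 2 to compound 3 (0.07 log units; within the scatter) all stay within the scatter, so the three compounds cannot be told apart on this read-out.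

Compound 4 `COc1ccc(OC)c(C(=O)/C=C/c2ccc(C(=O)OCC=C(C)C)cc2)c1` has not yet been measured in this assay. Compared with compound 1 it differs only at the ester: 2-methylprop-1-en-1-yl in place of hydrogen on a saturated chain carbon bound to an oxygen next to a carbonyl group.

The steps from compound 1 to compound 2 and to compound 3 are the ones that bear on this change, since both also enlarge the group on the oxygen next to the carbonyl group, and both gave only slightly higher numbers within the scatter. The new group in compound 4 is larger than either of those, so a somewhat higher number is the most plausible outcome, though the available steps give no reason to expect a move clearly beyond the scatter. Compound 4 is therefore expected to give about 7500 nM, between 3500 nM and 16000 nM, which would mean an estimated step of a 1.5-fold higher number from compound 1 to compound 4 (0.19 log units; within the scatter).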

Compound 4, half-maximal inhibitory concentration: > 50000 nM
Compound 4 ended at the assay's limit (the forecaster's own chance of this, stated with the estimate: 5%); middle value at least 6.6-fold (0.82 log units) from the limit.
By their numbers in this assay, from the lowest: compounds 1, 2 and 3 (each within the scatter of the next). At a limit, above all of these: compound 4.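

In this assay, compound 4 stands at a limit, not at a measured number: the limit of > 50000 nM in this assay, at which 1 of the 4 values shown sits. The methyl, ethyl and isopropyl esters could not be told apart, which made the ester look like a place where changes have little effect, but the 3-methylbut-2-en-1-yl ester breaks that picture, with an at least 10-fold higher number from compound 1 to compound 4 (1.01 log units; beyond the scatter), an at least 8.7-fold higher number from compound 2 to compound 4 (0.94 log units; beyond the scatter) and an at least 7.4-fold higher number from compound 3 to compound 4 (0.87 log units; beyond the scatter). All three steps lie beyond the scatter, so these four compounds show that a change at the ester alone, with the rest of the molecule the same, can shift this cytotoxicity read-out strongly, something compounds 1, 2 and 3 alone did not reveal.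

Compound 4 differs from the smaller esters in chain length, branching and a double bond all at once, so the compounds shown cannot say which of these features matters, and a saturated 3-methylbutyl ester or an unbranched butyl ester would help to separate them. As far as these compounds go, whether the sharp rise is specific to this one group also remains open, as does the effect of replacing the ester with a carboxylic acid or an amide.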